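This account rests on a few compounds, and the source may have more. Where it says the series, first, only, none or still open, it means among the compounds named here.

Series notes. Four bis-aryl amidines are compared in an ADME assay on cells (Erythrocyte, Homo sapiens) for activation, read by hemolysis, with a stated time of 30 min, tested at 10 mM; a lower number here means a weaker effect, a higher number a stronger effect of the compound at the concentration tested. Compound 1 `N=C(N)c1ccc(-c2ccc(-c3ccc(F)cc3)o2)o1` carries a fluoro group; in this assay compound 1 gives 90%. Compound 2 `COc1ccc(-c2ccc(-c3ccc(C(=N)N)o3)o2)cc1` is its methoxy analogue, and in this assay compound 2 gives 71.7%. The change between the two is methoxy in place of fluoro on an aromatic carbon, and it made a step of a number 18.3 percentage points lower from compound 1 to compound 2 (beyond the scatter).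

Compound 3 `N=C(N)c1ccc(-c2ccc(-c3ccc(F)cc3)s2)s1` is the fluoro compound on the second core; in this assay compound 3 gives 93.3%, which stands within the scatter of the number for compound 1 and beyond it from the number for compound 2. The difference between the two cores is not broken down here.

Compound 4 `COc1ccc(-c2ccc(-c3ccc(C(=N)N)s3)s2)cc1` has not yet been measured in this assay. It differs from compound 3 by methoxy in place of fluoro on an aromatic carbon, the same change, at the same place, as that from compound 1 to compound 2. Compound 4 is expected to give 75%, with a range from 60% to 90%. Compound 4 is thus expected to show a step of a number 18.3 percentage points lower from compound 3 to compound 4 (beyond the scatter). This expectation rests on the earlier step of a number 18.3 percentage points lower from compound 1 to compound 2 (beyond the scatter), which the same change made on the first core, applied to the number for compound 3, which is 93.3%. Whether the second core carries the change the same way is not known from these three numbers, so the range is kept wide.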

Compound 4, a percentage reported as activity, at one concentration (the size of the read-out at that concentration, not a potency): 92.7%
Estimate against measurement, compound 4: 17.7 percentage points below; the measured number lies above the stated range.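

On the core of compound 3, methoxy in place of fluoro on an aromatic carbon gave a number 0.6 percentage points lower from compound 3 to compound 4 (within the scatter) in this assay, so on this core the numbers for the fluoro and methoxy compounds cannot be told apart. The step seen on the core of compound 1 therefore did not carry over to the core of compound 3, and in this series a step read on one core is not a safe guide to the same change on the other: the same change on two cores in this assay, a number 18.3 percentage points lower (beyond the scatter) from compound 1 to compound 2 and a number 0.6 percentage points lower (within the scatter) from compound 3 to compound 4, 17.7 percentage points apart, beyond the scatter of two such steps This shows that the effect of the change depends on the core in this one pair of pairs, but it does not show which feature of the cores is responsible, why the two steps differ, or how any other change would transfer, since two steps on two cores cannot support a general rule.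

The compounds shown leave open whether other groups on an aromatic carbon of the six-membered aromatic ring of carbon only, such as chloro, hydroxyl, an amine or a carboxylic acid, would also separate the two cores or give no step on either. They also leave open whether the difference between the two steps would persist away from the single concentration and time used here, since the read-out is the size of an effect and not a potency.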